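Benzyl to pyrazolyl on the sulfonyl of a tetralin amine

The compounds below may be only part of what the source reports. "The series", "measured", "known", "first", "only" and "open" are said of these compounds alone.

Of the compounds shown here, three have been measured in an assay on isolated protein for displacement of a labelled ligand from 5-hydroxytryptamine receptor 6 (Homo sapiens); on this read-out lower numbers stand for stronger inhibition and higher numbers for weaker inhibition. Compound 1 `CN(C)CC1CCCc2cc(S(=O)(=O)c3ccccc3)ccc21` gives 0.0631 nM, and compound 2 `COc1cccc(S(=O)(=O)c2ccc3c(c2)CCC[C@H]3CN)c1` gives 0.398 nM. Compound 3 `NC[C@@H]1CCCc2cc(S(=O)(=O)Cc3ccccc3)ccc21` stands apart with the highest number of the three, giving 158 nM; its value lies far beyond the scatter from both others, and the distance to compound 2 is smaller than that to compound 1.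

Compound 4 `NC[C@@H]1CCCc2cc(S(=O)(=O)c3cn[nH]c3)ccc21` is not yet measured. It differs from compound 3 in one place: 1H-pyrazol-4-yl in place of benzyl on a sulfonyl sulfur. Among the measured compounds shown here, no measured pair tells the size of this exact step. Still, a large move toward lower numbers is expected, because compound 1 gives 0.0631 nM and compound 2 gives 0.398 nM with their sulfonyl groups bearing an aromatic ring rather than a benzyl. Compound 4 is therefore expected to come in near 5 nM, within a range of 0.5 nM to 50 nM. That estimate corresponds to an expected step of a 32-fold lower number from compound 3 to compound 4 (1.50 log units; beyond the scatter), well beyond the scatter.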

Compound 4, inhibition constant: 2 nM
Estimate against measurement, compound 4: 2.5-fold (0.40 log units) above; low and high end bracket the measured number.
By their numbers in this assay, from the lowest: compound 1; then compound 2; then compound 4; then compound 3.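

In this assay the group on the sulfonyl sulfur proves to be a strong control on the number: with the rest of the molecule unchanged, 1H-pyrazol-4-yl in place of benzyl gives a large step (a 79-fold lower number from compound 3 to compound 4 (1.90 log units; beyond the scatter)). Among the compounds shown here, the earlier compounds offered no pair that isolated this position, so this is the first direct reading of it. Because the step changes the ring size, the hetero atoms and the hydrogen-bond donor and acceptor counts all at once, it cannot show which of these changes matters, and nothing measured here explains the size of the shift.

On these data alone, it remains open whether a pyridin-3-yl or a 1-methyl-1H-pyrazol-4-yl on the same sulfonyl sulfur would read closer to compound 4 or to compound 3. As far as these compounds go, the mirror-image form of compound 4 also remains open.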